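Urea side-chain changes on a shared anilinoquinazoline core

The source may hold more compounds than are shown below. What is called first, only, known or untested is meant among the compounds shown, and "the series" means these compounds.

The two measured compounds share one core and differ only in the group on the outer urea nitrogen. Compound 1 `O=C(Nc1cccc(CN2CCCC2)c1)Nc1ccc2ncnc(Nc3cccc(C(F)(F)F)c3)c2c1` gives 860 nM in a functional assay on A549 cells (Homo sapiens) for antiproliferative activity, read by MTT assay, with a stated time of 72 h; on this read-out higher numbers stand for weaker inhibition and lower numbers for stronger inhibition. Compound 2 `CCN(CC)c1ccc(NC(=O)Nc2ccc3ncnc(Nc4cccc(C(F)(F)F)c4)c3c2)cc1` gives 3520 nM in this assay. Among the measured compounds shown here, on these two numbers compound 2 stands highest; the only step, a 4.1-fold higher number from compound 1 to compound 2 (0.61 log units; beyond the scatter), goes against compound 2 and lies beyond the scatter.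

Compound 3 `CN1CCN(CCNC(=O)Nc2ccc3ncnc(Nc4cccc(C(F)(F)F)c4)c3c2)CC1` is not yet measured. Relative to compound 2 the change is 2-(4-methylpiperazin-1-yl)ethyl in place of 4-(diethylamino)phenyl on an amide-type nitrogen. For the measured compounds named here, no measured step covers this kind of exchange: the one step known, a 4.1-fold higher number from compound 1 to compound 2 (0.61 log units; beyond the scatter), swaps one six-membered aromatic ring of carbon only for another and says nothing about a non-aromatic ring on a short chain. The expectation for compound 3 therefore rests on little more than the number of compound 2 itself, and a step no larger than the scatter, in either direction, is expected, a 1.2-fold lower number from compound 2 to compound 3 (0.07 log units; within the scatter), with a wide range. In this assay compound 3 is estimated at 3000 nM, between 700 nM and 13000 nM.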

Compound 3, half-maximal inhibitory concentration: > 10000 nM
Compound 3: only a limit was reported (the forecaster's own chance of this, stated with the estimate: 10%); middle value at least 3.3-fold (0.52 log units) from the limit.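

In this assay compound 3 gives > 10000 nM, which is a limit and not a number, and the series now has a value of this kind: the limit of > 10000 nM in this assay, at which 1 of the 3 values shown sits.

Until now this position had shown only an exchange between two groups with a six-membered aromatic ring of carbon only; with a non-aromatic ring on a short chain on the same amide-type nitrogen, the read-out gives an at least 2.8-fold higher number from compound 2 to compound 3 (0.45 log units; beyond the scatter) and also an at least 11-fold higher number from compound 1 to compound 3 (1.06 log units; beyond the scatter), the second being a larger step than a 4.1-fold higher number from compound 1 to compound 2 (0.61 log units; beyond the scatter). Both new steps lie beyond the scatter and point to weaker inhibition, so among these three compounds the lower numbers go with an aromatic ring on this nitrogen, in compound 1 and compound 2, and no compound shown goes against this.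

Compound 3 changes the ring and the chain in a single exchange, and the compounds shown do not separate the two. Still open, as far as these compounds go, is how a phenyl ring carrying 4-methylpiperazin-1-yl on this nitrogen would read, and how an ethyl chain ending in a diethylamine would read in the same place.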